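Aryl change on the ring nitrogen: compound 3 to compound 4

A few compounds are considered here, and "the series" means these few. Any claim that something is new, unique, unknown or untested is made for them only; others in the source may bear on it.

Compound 3 `COc1cc2c(Oc3ccc(NC(=O)c4nnn(-c5ccccc5C(F)(F)F)c4C(F)(F)F)cc3F)ccnc2cc1OCCCN1CCC(C)CC1` gives 220 nM in a functional assay on A549 cells (Homo sapiens) for cytotoxicity, read by MTT assay, with a stated time of 72 h (on this read-out lower numbers stand for stronger inhibition and higher numbers for weaker inhibition), the highest of the three numbers, though within the scatter of both others. Compound 1 `COc1cc2c(Oc3ccc(NC(=O)c4nnn(-c5ccccc5C(F)(F)F)c4C(F)(F)F)cc3F)ccnc2cc1OCCCN1CCCC1` gives 200 nM and compound 2 `COc1cc2c(Oc3ccc(NC(=O)c4nnn(-c5ccc(F)cc5)c4C(F)(F)F)cc3F)ccnc2cc1OCCCN1CCC(C)CC1` gives 120 nM. The two steps into compound 3 are small: a 1.1-fold higher number from compound 1 to compound 3 (0.04 log units; within the scatter) and a 1.8-fold higher number from compound 2 to compound 3 (0.26 log units; within the scatter). Compound 4 `COc1cc2c(Oc3ccc(NC(=O)c4nnn(-c5cccc(Br)c5)c4C(F)(F)F)cc3F)ccnc2cc1OCCCN1CCC(C)CC1` differs from compound 3 by 3-bromophenyl in place of 2-(trifluoromethyl)phenyl on an aromatic nitrogen. For the measured compounds named here, only the step from compound 2 to compound 3 bears on this, since it also exchanges the group on the aromatic nitrogen, and that step stayed within the scatter. A further aryl exchange is thus expected to move the number little; the estimated step is a 1.5-fold lower number from compound 3 to compound 4 (0.17 log units; within the scatter). Compound 4 is expected at 150 nM in this assay, with a range of 60 nM to 400 nM.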

Compound 4, half-maximal inhibitory concentration: 350 nM
Compound 4: middle estimate off by 2.3-fold (0.37 log units), on the low side; measured number inside the range.
By their numbers in this assay, from the lowest: compounds 2, 1, 3 and 4 (each within the scatter of the next, the first and the last beyond it).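

In this assay the aryl group on the aromatic nitrogen now yields a step beyond the scatter: 3-bromophenyl in place of 4-fluorophenyl gives a 2.9-fold higher number from compound 2 to compound 4 (0.46 log units; beyond the scatter) and is modest in size. The exchange for 2-(trifluoromethyl)phenyl stays within the scatter at a 1.6-fold higher number from compound 3 to compound 4 (0.20 log units; within the scatter) so only compound 2 and compound 4 stand apart among these aryl groups. Nothing available accounts for this step.

Still open, going by these compounds, is how an unsubstituted phenyl, a pyridyl ring or a simple methyl on this nitrogen would read. Also open, on these data alone, is whether the step from compound 2 to compound 4 persists with pyrrolidin-1-yl on the chain.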